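The source may hold more compounds than are shown below. What is called first, only, known or untested is meant among the compounds shown, and "the series" means these compounds.

Measured so far in an assay on HEK293 cells for agonist activity at Toll-like receptor 8 (Homo sapiens), read by a luciferase reporter, with a stated time of 6 h; a higher number here means that more compound is needed for the effect, a lower number that less compound is needed:
compound 1 `CCCCNc1nc(N)nc2ccn(Cc3ccccc3)c12` sits at the limit of the assay, > 25 uM.
compound 2 `CCCCNc1nc(N)nc2ccn(CCCc3ccccc3)c12` gives 3.78 uM.
compound 3 `CCCCNc1nc(N)nc2ccn(CC=C(C)C)c12` sits at the limit of the assay, > 25 uM.

Compound 3 therefore stands where no number was reached; it shares that position with compound 1 (the limit of > 25 uM in this assay, at which 2 of the 3 values shown sit). Among the measured compounds shown here, the one readable step to it, an at least 6.6-fold higher number from compound 2 to compound 3 (0.82 log units; beyond the scatter), shows that compound 3 needs a good deal more compound than compound 2, while a step that the two limits leave unreadable from compound 1 to compound 3 cannot be sized, as both ends are limits.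

Compound 4 `CCCCNc1nc(N)nc2ccn(Cc3ccsc3)c12` differs from compound 3 in one place: thiophen-3-yl in place of 2-methylprop-1-en-1-yl on a saturated chain carbon bound to an aromatic nitrogen. The result resembles compound 1, which carries phenyl on the same saturated chain carbon bound to an aromatic nitrogen, and compound 1 reached no number in this assay. The step of an at least 6.6-fold lower number from compound 1 to compound 2 (0.82 log units; beyond the scatter) shows that only a longer link, phenethyl in place of phenyl, brought a readable value. Compound 4 keeps the short link, so it is expected to behave like compound 1 and compound 3, and the step of a number no higher from compound 3 to compound 4 (the limit leaves the size open) is expected to stay within the scatter. Compound 4 is estimated at 25 uM, with a range from 6 uM to 60 uM.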

Compound 4, minimum effective concentration: > 25 uM
Compound 4: only a limit was reported; the forecaster's own chance of this, stated with the estimate: 60%; the middle value sits exactly at the limit.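

In this assay compound 4 gives > 25 uM, which is a limit of the assay and not a number, so a third group on the saturated chain carbon bound to an aromatic nitrogen ends at the same limit: the limit of > 25 uM in this assay, at which 3 of the 4 values shown sit.

Among the compounds shown here, the one readable step, an at least 6.6-fold higher number from compound 2 to compound 4 (0.82 log units; beyond the scatter), shows that swapping the phenethyl group for thiophen-3-yl costs a clear amount of activity, so among the four compounds phenethyl remains the only group at this place that reaches a value. The steps to compound 4 from compound 1 and from compound 3 have limits at both ends and cannot be read, so thiophen-3-yl, phenyl and 2-methylprop-1-en-1-yl cannot be put in any order.

Going by these compounds, what stays open is whether thiophen-3-yl fails as a ring or only through its short link to the core, since phenethyl differs from it in both respects. A thiophen-3-yl carried on a longer chain, or a longer chain ending in an amine, would help to separate these two readings in this assay.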